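Cyclopropyl for Isopropyl on a Core Without Measured Potency

The compounds below may be only part of what the source reports. "The series", "measured", "known", "first", "only" and "open" are said of these compounds alone.

Compound 1 `CCCc1nc(C)c2c(C(C)C)nnc(O)n12` was tested in a functional assay for inhibition, with Homo sapiens as the target; a higher number here means a weaker inhibitor, a lower number a stronger inhibitor. In this assay compound 1 gives > 48000 nM, which is a limit of the assay rather than a number. Compound 2 `CCCc1nc(C)c2c(C(C)C)nnc(S)n12` gives > 48000 nM, also a limit. Compound 3 `CCCc1nc(C)c2c(C(C)C)nnc(SC)n12` gives > 48000 nM, again a limit. All three values share (the limit of > 48000 nM in this assay, at which 3 of the 3 values shown sit). The steps a step that the two limits leave unreadable from compound 1 to compound 2, a step that the two limits leave unreadable from compound 1 to compound 3 and a step that the two limits leave unreadable from compound 2 to compound 3 are therefore unreadable in size. Compound 4 `CCCc1nc(C)c2c(C3CC3)nnc(O)n12` differs from compound 1 by cyclopropyl in place of isopropyl on an aromatic carbon. Going by the values given here, none of the measured steps touches this position, and none of them has a readable size. Compound 4 is therefore expected to remain at the same limit, with an estimated 60000 nM in a range of 20000 nM to 200000 nM, an expected step that the limit leaves unreadable from compound 1 to compound 4.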

Compound 4, half-maximal inhibitory concentration: > 48000 nM
Compound 4: no number, only a limit (the forecaster's own chance of this, stated with the estimate: 85%); the middle value does not contradict the limit.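

Compound 1 and compound 4 both sit at a limit of the assay, so the size of the change from isopropyl to cyclopropyl cannot be read: the limit of > 48000 nM in this assay, at which 4 of the 4 values shown sit.

The compounds shown leave open whether any change to the shared core gives a measurable value, and how these two groups would compare if one did.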